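A few compounds are considered here, and "the series" means these few. Any claim that something is new, unique, unknown or untested is made for them only; others in the source may bear on it.

Measured compounds:
- compound 1, `CN(C)C(=S)N/N=C/c1ccc2ccccc2n1`: 30 nM
- compound 2, `S=C(N/N=C/c1ccc2ccccc2n1)Nc1ccc(Cl)cc1`: 87600 nM
- compound 3, `S=C(NCc1ccccc1)N/N=C/c1ccc2ccccc2n1`: 53700 nM

In a functional assay on SGC-7901 cells (Homo sapiens) for antiproliferative activity, read by sulforhodamine B assay, with a stated time of 72 h (on this read-out higher numbers stand for weaker inhibition and lower numbers for stronger inhibition), compound 3 gives 53700 nM, the second-highest of the three numbers. Its nearest neighbour is compound 2, which gives 87600 nM in this assay, and the two lie within the usual scatter of each other. Compound 1, by contrast, gives 30 nM in this assay, a number far lower than that of compound 3.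

Compound 4, `S=C(N/N=C/c1ccc2ccccc2n1)Nc1ccccc1`, is not yet measured. It differs from compound 3 in one place: phenyl in place of benzyl on an amide-type nitrogen

For the measured compounds named here, the one measured step that bears on this change is a 1.6-fold lower number from compound 2 to compound 3 (0.21 log units; within the scatter). There, swapping one substituent for another on the same amide-type nitrogen of the shared core left the number essentially unchanged. The two measured compounds carrying an aryl or benzyl group on that nitrogen both sit at high numbers, far from compound 1. With phenyl taking the place of benzyl at the same position, no step beyond the scatter is expected in this assay.

Compound 4 is therefore estimated at 60000 nM, with a range from 20000 nM to 180000 nM, which amounts to an expected step of a 1.1-fold higher number from compound 3 to compound 4 (0.05 log units; within the scatter).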

Compound 4, half-maximal inhibitory concentration: 26500 nM
For compound 4 the middle estimate is 2.3-fold (0.35 log units) above the measured one; the range from low to high includes it.
By their numbers in this assay, from the lowest: compound 1; then compound 4; then compounds 3 and 2 (each within the scatter of the next).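

In this assay, for the compounds shown here, the earlier compounds showed only a swap on the amide-type nitrogen that stayed within the scatter, a 1.6-fold lower number from compound 2 to compound 3 (0.21 log units; within the scatter) and compound 4 shows that this part of the molecule does respond to small changes: phenyl in place of benzyl on that nitrogen gives a 2.0-fold lower number from compound 3 to compound 4 (0.31 log units; beyond the scatter) and hydrogen in place of chloro on an aromatic carbon gives a 3.3-fold lower number from compound 2 to compound 4 (0.52 log units; beyond the scatter) as a second modest step beyond the scatter. Both steps remain small beside the change of anilino in place of dimethylamino on the thiocarbonyl carbon, which gives an 880-fold higher number from compound 1 to compound 4 (2.95 log units; beyond the scatter) and leaves compound 4 far from the low number of compound 1, so the unsubstituted phenyl recovers only a little of that gap. Nothing available explains any of these steps.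

The compounds shown leave open how a methoxy group or a fluorine on the aromatic ring of compound 4 would read in this assay and whether the effect of removing chloro extends beyond this one pair. They also leave open where the large gap closes, as a single methylamino, a diethylamino or a piperidine ring on the thiocarbonyl carbon would be needed to test this.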